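A Fluorine Added to the Central Ring of Compound 2

A few compounds are considered here, and "the series" means these few. Any claim that something is new, unique, unknown or untested is made for them only; others in the source may bear on it.

Compound 1 `O=C(Nc1ccc(Oc2ccnc3[nH]ccc23)cc1)c1cc(-c2ccc(Cl)cc2)ncn1` gives 6530 nM in a functional assay on A549 cells (Homo sapiens) for cytotoxicity, read by MTT assay, with a stated time of 72 h; a lower number here means a stronger inhibitor, a higher number a weaker inhibitor.
Compound 2 `O=C(Nc1ccc(Oc2ccnc3[nH]ccc23)cc1)c1cc(-c2ccc(Br)cc2)ncn1` gives 9870 nM in this assay.
Compound 3 `Cc1ccc(-c2cc(C(=O)Nc3ccc(Oc4ccnc5[nH]ccc45)cc3)ncn2)cc1` gives 5410 nM in this assay.

These three compounds share one core and differ only in the group at the far end of the outer aromatic ring: chloro, bromo or methyl. Compound 2 sits at the high end of the three numbers, but a 1.5-fold higher number from compound 1 to compound 2 (0.18 log units; within the scatter) and a 1.8-fold lower number from compound 2 to compound 3 (0.26 log units; within the scatter) show that neither gap is larger than the usual scatter of repeated measurements, so the three cannot be told apart on these data. The third pair, a 1.2-fold lower number from compound 1 to compound 3 (0.08 log units; within the scatter), confirms the same picture: swapping one small group for another on the outer ring left the read-out essentially where it was.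

Compound 4 `O=C(Nc1ccc(Oc2ccnc3[nH]ccc23)c(F)c1)c1cc(-c2ccc(Br)cc2)ncn1` is not yet measured. It differs from compound 2 in a different place: fluoro in place of hydrogen on an aromatic carbon. Going by the values given here, no measured step changes this part of the molecule, so nothing here speaks directly to this change. Among the compounds with values here, the only guidance is indirect: every small substituent swap seen so far stayed within the scatter. Compound 4 is therefore expected to give a number close to that of compound 2, with a 1.2-fold lower number from compound 2 to compound 4 (0.06 log units; within the scatter) as the expected step. The estimate for compound 4 in this assay is 8500 nM, with a range from 3000 nM to 25000 nM.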

Compound 4, half-maximal inhibitory concentration: 6980 nM
Compound 4: the middle estimate sits 1.2-fold (0.09 log units) above what was measured; measured number inside the range.
By their numbers in this assay, from the lowest: compounds 3, 1, 4 and 2 (each within the scatter of the next).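

The earlier steps shown here all changed the far end of the outer ring, whereas this one changes the six-membered aromatic ring of carbon only, and in this assay it gives a 1.4-fold lower number from compound 2 to compound 4 (0.15 log units; within the scatter). Fluoro in place of hydrogen on this carbon, ortho to a large group and meta to a large group, therefore leaves compound 4 indistinguishable from compound 2, so the read-out gives no sign that this position is sensitive to this one small swap. This is a single pair carrying bromo on the outer ring, and nothing shown here explains the result.

The compounds shown leave open whether this carbon would tolerate anything other than fluoro, such as a methoxy group, an amine or a carboxylic acid, any of which could show whether the position matters at all. They also leave open whether fluoro on this ring would give the same picture with the chloro of compound 1 or the methyl of compound 3 at the far end of the outer ring.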